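Chlorine pattern on the benzyl ether: towards compound 4

The compounds below may be only part of what the source reports. "The series", "measured", "known", "first", "only" and "open" are said of these compounds alone.

Compound 1 `Cc1ccc(NC(=O)NC(=O)c2ccc(OCc3ccccc3)cc2)cc1-c1nc2ccccc2[nH]1` in a functional assay on MGC-803 cells (Homo sapiens) for inhibition, read by MTT assay, with a stated time of 48 h (a lower number here means a stronger inhibitor, a higher number a weaker inhibitor), gives 39400 nM.
Compound 2 `Cc1ccc(NC(=O)NC(=O)c2ccc(OCc3cccc(Cl)c3)cc2)cc1-c1nc2ccccc2[nH]1` in this assay gives 20800 nM.
Compound 3 `Cc1ccc(NC(=O)NC(=O)c2ccc(OCc3cccc(Cl)c3Cl)cc2)cc1-c1nc2ccccc2[nH]1` in this assay gives only a limit, > 100000 nM.

Compound 3 sits at the limit of this assay, (the limit of > 100000 nM in this assay, at which 1 of the 3 values shown sits), and is the only one of the three without a number. The step of an at least 2.5-fold higher number from compound 1 to compound 3 (0.40 log units; beyond the scatter) and the step of an at least 4.8-fold higher number from compound 2 to compound 3 (0.68 log units; beyond the scatter) both run upward beyond the scatter, whereas the step of a 1.9-fold lower number from compound 1 to compound 2 (0.28 log units; within the scatter) stays within it.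

Compound 4 `Cc1ccc(NC(=O)NC(=O)c2ccc(OCc3ccccc3Cl)cc2)cc1-c1nc2ccccc2[nH]1` differs from compound 3 by hydrogen in place of chloro on an aromatic carbon, read one bond further out as 2,3-dichlorobenzyl to 2-chlorobenzyl. Within the data shown here, the chloro that compound 4 loses is the one the step of a 1.9-fold lower number from compound 1 to compound 2 (0.28 log units; within the scatter) introduced without effect beyond the scatter; the chloro that compound 4 keeps is the one added in the step of an at least 4.8-fold higher number from compound 2 to compound 3 (0.68 log units; beyond the scatter), which went upward. Compound 4 is therefore expected to come off the limit while staying weak, with an expected value around 60000 nM and an expected range of 25000 nM to 150000 nM. The expected step of an at least 1.6-fold lower number from compound 3 to compound 4 (0.22 log units; that floor lies within the scatter) is estimated as a modest move downward.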

Compound 4, half-maximal inhibitory concentration: 19500 nM
Compound 4: the middle estimate sits 3.1-fold (0.49 log units) above what was measured; measured number outside the range, below it.
By their numbers in this assay, from the lowest: compounds 4, 2 and 1 (each within the scatter of the next, the first and the last beyond it). At a limit, above all of these: compound 3.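

Hydrogen in place of chloro on the 2,3-dichlorobenzyl group gives an at least 5.1-fold lower number from compound 3 to compound 4 (0.70 log units; beyond the scatter) in this assay, a step read from a limit and therefore only a floor. Set against the other single-chloro compound, 2-chlorophenyl in place of 3-chlorophenyl gives a 1.1-fold lower number from compound 2 to compound 4 (0.03 log units; within the scatter), while against the unsubstituted benzyl of compound 1 the step is a 2.0-fold lower number from compound 1 to compound 4 (0.31 log units; beyond the scatter). The upward move to the limit appears only in compound 3, which carries both chloro groups, so the same chloro change runs in opposite directions on different cores: the same change on two cores in this assay, an at least 4.8-fold higher number (0.68 log units; beyond the scatter) from compound 2 to compound 3 and a 2.0-fold lower number (0.31 log units; beyond the scatter) from compound 1 to compound 4, at least 9.7-fold (0.98 log units) apart, beyond the scatter of two such steps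

As far as these compounds go, the true number behind the limit of compound 3 remains open. Also open, from the compounds shown here alone, is whether two fluoro or two methoxy groups in these places would give the same upward move as the two chloro groups.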